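This account rests on a few compounds, and the source may have more. Where it says the series, first, only, none or still open, it means among the compounds named here.

In a functional assay on SW-620 cells (Homo sapiens) for cytotoxicity, read by MTT assay, with a stated time of 72 h (a lower number here means a stronger inhibitor, a higher number a weaker inhibitor), two compounds have been measured.

Compound 1 `COc1ccc(/C=C2\CCC/C(=C\c3ccc(OC)c(OC)c3)C2=O)cc1` gives 6600 nM

Compound 2 `COc1ccc(/C=C2\CCC/C(=C\c3ccc(O)c(Cl)c3)C2=O)cc1OC` gives 7100 nM

Compound 2 stands level with compound 1, the two values lying within the scatter of each other. Compound 3 `COc1cc(/C=C2\CCC/C(=C\c3ccc(OC)c(OC)c3)C2=O)ccc1O` carries methoxy in place of chloro on an aromatic carbon, ortho to a hydroxy group, the counted difference being methoxy in place of chloro on an aromatic carbon in all. Among the measured compounds shown here, the one measured step that bears on this, a 1.1-fold higher number from compound 1 to compound 2 (0.03 log units; within the scatter), put 3-chloro-4-hydroxyphenyl in place of 4-methoxyphenyl, so no step beyond the scatter is expected in this assay here. The expected change is a 1.3-fold lower number from compound 2 to compound 3 (0.11 log units; within the scatter) without a firm direction. For compound 3 the estimate is 5500 nM with an expected range from 2200 nM to 13000 nM overall.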

Compound 3, half-maximal inhibitory concentration: 4500 nM
The estimate for compound 3 lay 1.2-fold (0.09 log units) above the measured number; the range from low to high includes it.
By their numbers in this assay, from the lowest: compounds 3, 1 and 2 (each within the scatter of the next).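

In this assay methoxy in place of chloro on this aromatic carbon, ortho to a hydroxy group, gives a 1.6-fold lower number from compound 2 to compound 3 (0.20 log units; within the scatter) and so does not separate the two groups here. Likewise, 4-hydroxy-3-methoxyphenyl in place of 4-methoxyphenyl gives a 1.5-fold lower number from compound 1 to compound 3 (0.17 log units; within the scatter) and shows no change beyond the scatter on that side of the core. Nothing available explains these results.

On these data alone, whether an amine or a carboxylic acid on this aromatic carbon would move the number beyond the scatter remains open.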